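The source may report more compounds than this note shows. Statements on the series, on what has been measured and on what is new or still open speak of the compounds shown alone.

Working notes on the series.

Three compounds carry a measured dose so far. Compound 1 `CCc1nncn1-c1ccc(OCc2ccc(F)cc2)cc1` gives 22.8 mg/kg in a functional assay on the whole organism (strain C57B/6) with Mus musculus as the target, in the maximal electroshock model (a lower number here means that less compound is needed, a higher number that more compound is needed for the effect), which puts it second highest of the three numbers. Nearest to it stands compound 3 `CCc1nncn1-c1ccc(OCc2ccc(C)cc2)cc1` at 25.5 mg/kg. Furthest from it stands compound 2 `CCc1nncn1-c1ccc(OCc2ccccc2Cl)cc1` at 13.2 mg/kg. The steps among the measured compounds are small: a 1.7-fold lower number from compound 1 to compound 2 (0.24 log units; within the scatter), a 1.1-fold higher number from compound 1 to compound 3 (0.05 log units; within the scatter), and a 1.9-fold higher number from compound 2 to compound 3 (0.29 log units; within the scatter). Each of these exchanges one ring for another on the saturated chain carbon bound to the oxygen, or one substituent on that ring for another, and none moves the dose beyond the scatter.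

Compound 4 `CCCOc1ccc(-n2cnnc2CC)cc1` differs from compound 1 in one place: ethyl in place of 4-fluorophenyl on a saturated chain carbon bound to an oxygen on an aromatic ring. For the measured compounds named here, no measured step removes the ring altogether, so the three steps bear on this change only loosely; they show that the identity of the ring matters little, not what happens when it is gone. The expectation for compound 4 is therefore a higher number, a 1.8-fold higher number from compound 1 to compound 4 (0.24 log units; within the scatter), with wide uncertainty. Compound 4 is estimated at 40 mg/kg, expected between 15 mg/kg and 120 mg/kg.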

Compound 4, dose for half-maximal effect: > 100 mg/kg
Compound 4 ended at the assay's limit (the forecaster's own chance of this, stated with the estimate: 15%); at least 2.5-fold (0.39 log units) between middle value and limit.
By their numbers in this assay, from the lowest: compounds 2, 1 and 3 (each within the scatter of the next). At a limit, above all of these: compound 4.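

At this position, the saturated chain carbon bound to the oxygen, exchanges of one aromatic ring for another stayed within the scatter, but ethyl in place of the ring gives steps beyond the scatter in all three comparisons: an at least 4.3-fold higher number from compound 1 to compound 4 (0.64 log units; beyond the scatter), an at least 3.9-fold higher number from compound 3 to compound 4 (0.59 log units; beyond the scatter) and an at least 7.5-fold higher number from compound 2 to compound 4 (0.87 log units; beyond the scatter). In this assay, the three compounds with an aromatic ring here all give numbers, while ethyl, with no ring, does not, so the ring and ethyl are not interchangeable at this position. Compound 4 carries a limit and not a number, and each of the three steps is only a minimum: the limit of > 100 mg/kg in this assay, at which 1 of the 4 values shown sits.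

Open, as far as these compounds go, is whether a cyclohexyl ring or a longer chain on this carbon would give a number in the range of compound 1, compound 2 and compound 3. Also open, from the compounds shown here alone, is how a second substituent, such as an amine, on the aromatic ring would behave.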